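The source may report more compounds than this note shows. Statements on the series, on what has been measured and on what is new or still open speak of the compounds shown alone.

Measured in a functional assay on THP-1 cells (Homo sapiens) for activation, with a stated time of 18 h; on this read-out lower numbers stand for an effect already at smaller amounts and higher numbers for an effect only at larger amounts of compound:
Compound 1 `CC(C)(C)OC(=O)n1c(-c2ccc3c(c2)CC(NS(=O)(=O)c2ccccc2)C3)cc2ccccc21`: 680 nM
Compound 2 `CC(C)(C)OC(=O)n1c(-c2ccc3c(c2)CC(NS(=O)(=O)c2ccc(F)cc2)C3)cc2ccccc21`: 570 nM

Within the data shown here, only these two compounds have numbers so far. Among the measured compounds shown here, compound 2, at 570 nM, stands within the scatter of compound 1, its only neighbour on the scale. Compound 3 `CC(C)(C)OC(=O)n1c(-c2ccc3c(c2)CC(NS(=O)(=O)c2c(F)cccc2F)C3)cc2ccccc21` keeps the shared core and differs from compound 2 in one group: 2,6-difluorophenyl in place of 4-fluorophenyl on a sulfonyl sulfur.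

For the measured compounds named here, one measured step bears on this change, fluoro in place of hydrogen on an aromatic carbon, and it amounts to a 1.2-fold lower number from compound 1 to compound 2 (0.08 log units; within the scatter). Going by the values given here, that single step gives no sign that this assay responds to fluorine on this ring, but it is thin evidence, as no measured compound carries the 2,6-difluorophenyl group. No step beyond the scatter is therefore expected, in either direction, and the range is kept wide. The expected change is a 1.1-fold higher number from compound 2 to compound 3 (0.02 log units; within the scatter). Compound 3 is estimated at 600 nM, with an expected range from 250 nM to 1500 nM.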

Compound 3, half-maximal effective concentration: 210 nM
For compound 3 the middle estimate is 2.9-fold (0.46 log units) above the measured one, and the stated range ends above it.
By their numbers in this assay, from the lowest: compound 3; then compounds 2 and 1 (each within the scatter of the next).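

The aryl group on the sulfonyl sulfur turns out to matter in this assay: the change to 2,6-difluorophenyl gives a 2.7-fold lower number from compound 2 to compound 3 (0.43 log units; beyond the scatter), whereas the earlier change from phenyl to 4-fluorophenyl stayed within the scatter. Measured against the unsubstituted phenyl group, the change gives a 3.2-fold lower number from compound 1 to compound 3 (0.51 log units; beyond the scatter), so fluorine on this ring can shift the number beyond the scatter, though only one of the two fluorinated groups shown does so. No information is available on why 2,6-difluorophenyl differs from 4-fluorophenyl here.

The step from compound 2 to compound 3 changes both the number of fluorines and where they stand, so these two differences cannot be told apart, and 2-fluorophenyl or 2,6-dichlorophenyl on the sulfonyl sulfur would be needed to take that question further. On these data alone, it also remains open whether the step holds in other settings, such as with an amine or a carboxylic acid in place of the tert-butyl ester group on the shared core, or whether a pyridine ring on the sulfonyl sulfur would serve as well.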